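This account rests on a few compounds, and the source may have more. Where it says the series, first, only, none or still open, it means among the compounds named here.

Working notes on the series. Compound 3 `O=[N+]([O-])c1cc(-c2nnc(SCc3ccc(Cl)c(Cl)c3)n2Cc2ccccc2)cc(C(F)(F)F)c1` in an ADME assay on A-431 cells (Homo sapiens) for cytotoxicity, with a stated time of 48 h (on this read-out lower numbers stand for stronger inhibition and higher numbers for weaker inhibition), returns only a limit of the assay, > 30000 nM. Compound 2 `O=[N+]([O-])c1cc(-c2nnc(SCc3ccc(Cl)cc3)n2Cc2ccccc2)cc(C(F)(F)F)c1` in this assay likewise returns only a limit, > 30000 nM. Compound 1 `O=[N+]([O-])c1cc(-c2nnc(SCc3ccccc3)n2Cc2ccccc2)cc([N+](=O)[O-])c1` in this assay also returns only a limit, > 30000 nM. Compound 3 thus stands at the limit together with both other values, and the step that the two limits leave unreadable from compound 2 to compound 3 cannot be read, as the limit of > 30000 nM in this assay, at which 3 of the 3 values shown sit, shows.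

Compound 4 `O=[N+]([O-])c1cc(-c2nnc(SCc3ccccc3)n2Cc2ccccc2)cc(C(F)(F)F)c1` differs from compound 3 by phenyl in place of 3,4-dichlorophenyl on a saturated chain carbon bound to a sulfur. Among the compounds with values here, no measured step in this assay gives a readable size or direction, and every value sits at the limit, so nothing beyond the scatter is foreseen. Compound 4 is expected to stay at the limit, with an estimate of 50000 nM and a range from 20000 nM to 150000 nM. The step expected is a step that the limit leaves unreadable from compound 3 to compound 4, within the scatter.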

Compound 4, half-maximal inhibitory concentration: 10100 nM
The estimate for compound 4 lay 5.0-fold (0.69 log units) above the measured number, outside the stated range (below it).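

Among the compounds shown, only the pairing of benzylsulfanyl with trifluoromethyl gives a readable number in this assay: the limit of > 30000 nM in this assay, at which 3 of the 4 values shown sit.

Phenyl in place of 3,4-dichlorophenyl gives an at least 2.9-fold lower number from compound 3 to compound 4 (0.47 log units; beyond the scatter), hydrogen in place of chloro gives an at least 2.9-fold lower number from compound 2 to compound 4 (0.47 log units; beyond the scatter), and trifluoromethyl in place of nitro gives an at least 2.9-fold lower number from compound 1 to compound 4 (0.47 log units; beyond the scatter). Each of these sizes is only a bound, and the step between the two chlorinated compounds, compound 2 and compound 3, cannot be read.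

Still open, as far as these compounds go, is how the number responds to an amine or a carboxylic acid on the phenyl ring of the benzyl group, or to a longer chain between the sulfur and that ring.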